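A few compounds are considered here, and "the series" means these few. Any claim that something is new, unique, unknown or untested is made for them only; others in the source may bear on it.

Compound 1 `C=C(CC)C(=O)c1ccc(OCc2nc(-c3ccc([N+](=O)[O-])cc3)cs2)cc1Cl` gives 10.2% in an assay on HL-60 cells for inhibition of glutathione S-transferase P (Homo sapiens), read by spectrophotometry, tested at 5 uM (on this read-out lower numbers stand for less inhibition and higher numbers for more inhibition at the one concentration tested (going by the name of the read-out)), the lowest of the three numbers measured. Its nearest neighbour is compound 2 `C=C(CC)C(=O)c1ccc(OCc2nc(-c3ccc(C(F)(F)F)cc3)cs2)cc1Cl` with 19.7%, a change of a number 9.5 percentage points higher from compound 1 to compound 2 (within the scatter). Compound 3 `C=C(C)C(=O)c1ccc(OCc2nc(-c3ccc([N+](=O)[O-])cc3)cs2)cc1Cl` gives 86.7%, reached by a number 76.5 percentage points higher from compound 1 to compound 3 (beyond the scatter). Compound 4 `C=C(CC)C(=O)c1ccc(OCc2nc(-c3ccc([N+](=O)[O-])cc3)cs2)c(Cl)c1Cl` differs from compound 1 by chloro in place of hydrogen on an aromatic carbon. Neither measured step bears directly on this change: the step from compound 1 to compound 2 alters a group on the distant aromatic ring and stays within the scatter, while the large step from compound 1 to compound 3 concerns the saturated chain carbon, not the ring carrying the chloro group. Compound 4 is therefore expected to move by about a number 4.8 percentage points higher from compound 1 to compound 4 (within the scatter), and its estimated value is 15%, within 2% to 40%.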

Compound 4, a percentage reported as inhibition, at one concentration (the size of the read-out at that concentration, not a potency): 8.1%
Beside the measured number, compound 4's estimate is 6.9 percentage points above it; measured number inside the range.
By their numbers in this assay, from the lowest: compounds 4, 1 and 2 (each within the scatter of the next, the first and the last beyond it); then compound 3.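

In this assay chloro in place of hydrogen on an aromatic carbon, ortho to a chloro group, gives a number 2.1 percentage points lower from compound 1 to compound 4 (within the scatter) and so does not shift the number beyond the scatter. Within the data shown here, this is the first reading at this position, as the earlier steps changed other places, but it comes from compound 1, which already stands low. No data given here explain the result. From the compounds shown here alone, whether this chloro would act alike on compound 3 stays open. So does the effect of a different group here, such as an amine or a methoxy group.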